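Series notes: methoxy for chloro on the core of compound 1

A few compounds are considered here, and "the series" means these few. Any claim that something is new, unique, unknown or untested is made for them only; others in the source may bear on it.

For the measured compounds named here, compound 1 `CC#C[C@@H](CC(=O)O)c1ccc(OC[C@H]2COc3ccc(Cl)cc3O2)cc1` stands highest of the two numbers so far in a functional assay on HEK293 cells for agonist activity at Free fatty acid receptor 1 (Homo sapiens), read by fluorescence and calcium flux, with a stated time of 10 min (a higher number here means a larger maximal response, a lower number a smaller maximal response), where compound 1 gives 86%. Going by the values given here, its mirror image, compound 2 `CC#C[C@H](CC(=O)O)c1ccc(OC[C@@H]2COc3ccc(Cl)cc3O2)cc1`, gives 41% in this assay; the step of a number 45 percentage points lower from compound 1 to compound 2 (beyond the scatter) goes with the fact that compounds 1 and 2 differ only in the configuration as drawn, and that is the only measured step in the set.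

Compound 3 `CC#C[C@@H](CC(=O)O)c1ccc(OC[C@H]2COc3ccc(OC)cc3O2)cc1` keeps the configuration of compound 1 and changes one group: methoxy in place of chloro on an aromatic carbon. Among the compounds with values here, no measured step speaks to a substituent exchange on that aromatic carbon; the single step available concerns configuration alone and is silent on what a methoxy in place of chloro does to the maximal response. With no comparable pair to lean on, the working expectation is a step from compound 1 to compound 3 of no size beyond the usual scatter, written as a number 6 percentage points lower from compound 1 to compound 3 (within the scatter), and the spread around it is kept wide for that reason.

Compound 3 is therefore estimated to give 80% in this assay, with a range of 55% to 100%.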

Compound 3, largest response reached (Emax), in percent of the reference or control that the assay uses: 91%
Beside the measured number, compound 3's estimate is 11 percentage points below it; measured number inside the range.
By their numbers in this assay, from the lowest: compound 2; then compounds 1 and 3 (each within the scatter of the next).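

In this assay, methoxy in place of chloro on an aromatic carbon gives a number 5 percentage points higher from compound 1 to compound 3 (within the scatter), so at this position the exchange leaves the maximal response indistinguishable from that of the chloro compound. For the compounds shown here, compounds 1 and 2 spoke only to configuration; this pair is the first reading of a substituent exchange on the aromatic carbon, and it shows that, with the configuration of compound 1 kept, methoxy, with 2 heavy atoms and 1 hydrogen-bond acceptor, can stand where chloro, with 1 heavy atom and 0 hydrogen-bond acceptors, stood. Nothing at hand accounts for this result, since the only available line of reasoning concerns configuration and not this exchange.

Going by these compounds, it remains open whether a different group on this aromatic carbon, such as an amine, a carboxylic acid or a longer chain like butoxy, would also leave the maximal response in place. On these data alone, it is equally open whether the configuration step, a number 45 percentage points lower from compound 1 to compound 2 (beyond the scatter), carries over to the methoxy series.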